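From Thiophen-2-yl to Thiophen-3-yl: What to Expect

The source may report more compounds than this note shows. Statements on the series, on what has been measured and on what is new or still open speak of the compounds shown alone.

Measured so far in an assay on membranes from CHO cells for displacement of a labelled ligand from adenosine receptor A1 (Homo sapiens), read by scintillation counting, with a stated time of 60 min, tested at 1 uM; on this read-out lower numbers stand for less inhibition and higher numbers for more inhibition at the one concentration tested (going by the name of the read-out):
- compound 1 `CC1=C(C(=O)NC(C)C)C(c2ccsc2)NC(=O)N1` gives 8%
- compound 2 `CC1=C(C(=O)OC2CCC2)C(c2ccoc2)NC(=O)N1` gives 20%
- compound 3 `CC1=C(C(=O)OC2CCC2)C(c2cccs2)NC(=O)N1` gives 24%

Compound 3 has the highest number of the three in this assay. For the measured compounds named here, its nearest neighbour is compound 2, and the one measured step between them, a number 4 percentage points higher from compound 2 to compound 3 (within the scatter), lies within the scatter, so the two cannot be told apart. Compound 1 stands further off, and that gap is beyond the scatter.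

Compound 4 `CC1=C(C(=O)OC2CCC2)C(c2ccsc2)NC(=O)N1` has not been measured. It differs from compound 3 in one place: thiophen-3-yl in place of thiophen-2-yl on a saturated ring carbon. Going by the values given here, the only measured step that touches this carbon, a number 4 percentage points higher from compound 2 to compound 3 (within the scatter), swapped one five-membered aromatic ring for another and moved the number by an amount within the scatter. Compound 1 also carries thiophen-3-yl, but it differs from compound 4 in a second place as well, so its value and that of compound 3 show only a gap beyond the scatter and not the effect of this change alone. On that slim basis, a step of a number 4 percentage points lower from compound 3 to compound 4 (within the scatter) is expected, that is, nothing beyond the scatter. Compound 4 is therefore estimated at 20% in this assay, with a range from 8% to 32%.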

Compound 4, a percentage reported as inhibition, at one concentration (the size of the read-out at that concentration, not a potency): 40%
Beside the measured number, compound 4's estimate is 20 percentage points below it, outside the stated range (above it).
By their numbers in this assay, from the lowest: compound 1; then compounds 2 and 3 (each within the scatter of the next); then compound 4.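

In this assay this saturated ring carbon turns out to be sensitive to more than the kind of ring it carries: thiophen-3-yl in place of thiophen-2-yl has the same atoms joined differently and still gives a number 16 percentage points higher from compound 3 to compound 4 (beyond the scatter) on the shared core. The choice of ring also counts once thiophen-3-yl is the group compared, since thiophen-3-yl in place of furan-3-yl gives a number 20 percentage points higher from compound 2 to compound 4 (beyond the scatter) while thiophen-2-yl in place of furan-3-yl gave only a number 4 percentage points higher from compound 2 to compound 3 (within the scatter) and so the earlier swap had hidden what this carbon can do. For the compounds shown here, the carbonyl carbon matters as well, as cyclobutyloxy in place of isopropylamino with thiophen-3-yl kept in place gives a number 32 percentage points higher from compound 1 to compound 4 (beyond the scatter) and this is the first step that isolates that change. Nothing available here explains any of these steps.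

As far as these compounds go, whether a phenyl or a pyridin-3-yl on the saturated ring carbon would match thiophen-3-yl remains open. From the compounds shown here alone, it is also open whether cyclobutyloxy in place of isopropylamino would give a similar step with thiophen-2-yl on that carbon, and whether a longer chain on the carbonyl carbon would go further.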